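From a Sulfamoyl Group to a Larger Fluorinated Chain

This account rests on a few compounds, and the source may have more. Where it says the series, first, only, none or still open, it means among the compounds named here.

Of the compounds shown here, three built on a related core have been measured in an ADME assay (liver) for metabolic stability, with Liver microsome (Rattus norvegicus) as the target, using microsomes and NADPH, with a stated time of 30 min; on this read-out lower numbers stand for slow clearance and higher numbers for fast clearance. Compound 3 `CC#C[C@H]1CN(S(=O)(=O)c2ccc(N)nc2)CCN1c1ccc(S(N)(=O)=O)cc1` gives 30 mL.min-1.g-1, and compound 1 `CC#C[C@H]1CN(S(=O)(=O)c2ccc(N)nc2)CCN1c1ccc(S(=O)(=O)NC)cn1` gives 42 mL.min-1.g-1, two numbers that lie within the usual scatter of each other. Compound 2 `CC#C[C@H]1CN(S(=O)(=O)c2ccc(N)nc2)CCN1c1ncc(C(C)(O)C(F)(F)F)s1` gives 87 mL.min-1.g-1, which is beyond the scatter from compound 3. Compound 3 therefore stands with compound 1 at the slow-clearance end of this small set.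

Compound 4 `CC#CCC(O)(c1ccc(N2CCN(S(=O)(=O)c3ccc(N)nc3)C[C@@H]2C#CC)cc1)C(F)(F)F` has not yet been measured. It keeps the core of compound 3 but loses the sulfamoyl group, and a larger group without a ring enters on the same aromatic carbon, para to a large group. The change is a group of 10 heavy atoms (6 carbon, 1 oxygen, 3 fluorine; no ring) in place of a group of 4 heavy atoms (1 nitrogen, 2 oxygen, 1 sulfur; no ring), on an aromatic carbon.

Among the compounds with values here, no measured pair of compounds shows this change on its own, so any expectation is indirect. The nearest guide is compound 2, which also holds a trifluoromethyl group and gives 87 mL.min-1.g-1 in this assay. An upward move towards faster clearance is expected, with an estimated 3.2-fold higher number from compound 3 to compound 4 (0.50 log units; beyond the scatter), although a step within the scatter remains possible. The estimate for compound 4 is 95 mL.min-1.g-1, with an expected range from 45 mL.min-1.g-1 to 190 mL.min-1.g-1.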

Compound 4, intrinsic clearance in microsomes: 115 mL.min-1.g-1
Compound 4: the middle estimate sits 1.2-fold (0.08 log units) below what was measured; the measured number falls inside the stated range.
By their numbers in this assay, from the lowest: compounds 3 and 1 (each within the scatter of the next); then compounds 2 and 4 (each within the scatter of the next).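

In this assay the exchange of the sulfamoyl group for the larger fluorinated chain gives a 3.8-fold higher number from compound 3 to compound 4 (0.58 log units; beyond the scatter), a modest step but one that lies beyond the usual scatter. Within the data shown here, compound 3 and compound 4 form the first pair in this set that differs in one place only, whereas compound 1 and compound 2 each differ from compound 3 in more than one part, so this pair gives the first direct sign that the group on this aromatic carbon, para to a large group, can by itself shift clearance, here towards the faster side. No measurement shown here accounts for the rise.

The whole group changes in a single step, so the compounds shown do not separate the share of the trifluoromethyl, the hydroxyl and the triple bond within the new chain. They also leave open where a different group on the same carbon, such as a carboxylic acid, an amine or a plain methyl, would fall relative to the sulfamoyl group and the fluorinated chain.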